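Removing One Methoxy Group: A Small Measured Step

A few compounds are considered here, and "the series" means these few. Any claim that something is new, unique, unknown or untested is made for them only; others in the source may bear on it.

Of the compounds shown here, three have been measured in a functional assay on SW-620 cells (Homo sapiens) for inhibition, read by sulforhodamine B assay, with a stated time of 48 h; a higher number here means a weaker inhibitor of growth, a lower number a stronger inhibitor of growth. Compound 1 `COc1cc(-c2cc(/C=C/C(=O)c3ccc(N)cc3)[nH]n2)cc(OC)c1OC` gives 2050 nM in this assay. Compound 2 `COc1ccc(-c2cc(/C=C/C(=O)c3ccc(N)cc3)[nH]n2)cc1OC` gives 2500 nM in this assay. Compound 3 `COc1cc(C(=O)/C=C/c2cc(-c3cc(OC)c(OC)c(OC)c3)n[nH]2)cc(OC)c1OC` gives 1590 nM in this assay. The three values lie close together, and none of them stands apart from the others beyond the usual scatter.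

Compound 2 is derived from compound 1 by one change: hydrogen in place of methoxy on an aromatic carbon That change made a step of a 1.2-fold higher number from compound 1 to compound 2 (0.09 log units; within the scatter).

Compound 4 `COc1ccc(-c2cc(/C=C/C(=O)c3cc(OC)c(OC)c(OC)c3)[nH]n2)cc1OC` is not yet measured. It differs from compound 3 by hydrogen in place of methoxy on an aromatic carbon This is the same change that separates compound 1 and compound 2, made at the same kind of place; the difference between the cores of compound 3 and compound 1 is not broken down here.

Because a 1.2-fold higher number from compound 1 to compound 2 (0.09 log units; within the scatter) stayed within the scatter, a step of similar size is expected here, a 1.2-fold higher number from compound 3 to compound 4 (0.08 log units; within the scatter). The estimate for compound 4 in this assay is therefore 1900 nM, expected to fall between 900 nM and 4000 nM.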

Compound 4, concentration for 50% growth inhibition: 1500 nM
Beside the measured number, compound 4's estimate is 1.3-fold (0.10 log units) above it; the measured number falls inside the stated range.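

In this assay, putting hydrogen in place of methoxy gave a 1.1-fold lower number from compound 3 to compound 4 (0.03 log units; within the scatter). Set beside the same change on the core of compound 1, the two steps do not differ, so in these two pairs the change carries from one core to the other without a readable difference: the same change on two cores in this assay, a 1.2-fold higher number (0.09 log units; within the scatter) from compound 1 to compound 2 and a 1.1-fold lower number (0.03 log units; within the scatter) from compound 3 to compound 4, 1.3-fold (0.11 log units) apart, within the scatter of two such steps. Going by these compounds alone, both steps lie within the scatter, so this shows only that the swap left the growth-inhibition number unchanged within that scatter on these two cores, and it does not show that the same would hold on any other core or in any other assay.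

What the compounds shown leave open is whether a group other than hydrogen, such as a hydroxyl group, a chlorine atom or a longer ethoxy chain, would leave the number as unchanged in that place. They also leave open what would happen if further methoxy groups on that ring were replaced as well.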